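A Fluoro Group Added to Compound 2

This account rests on a few compounds, and the source may have more. Where it says the series, first, only, none or still open, it means among the compounds named here.

In an ADME assay on HepG2 cells (Homo sapiens) for inhibition, read by resazurin assay, with a stated time of 48 h (on this read-out higher numbers stand for an effect only at larger amounts of compound and lower numbers for an effect already at smaller amounts), compound 2 `O=C(Nc1ccc2sc(-c3ccccc3)nc2c1)N1CCCC1` gives > 50000 nM and this is a limit of the assay, not a number. Compound 2 therefore has no exact standing on the numbers shown. Compound 1 `O=C(Nc1ccc2sc(-c3ccc(F)c(F)c3)nc2c1)N1CCCC1` carries 3,4-difluorophenyl where compound 2 carries phenyl. Compound 1 gives > 50000 nM and this too is a limit. Within the data shown here, the only measured step is a step that the two limits leave unreadable from compound 1 to compound 2 and it gives no size to build on.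

Compound 3 `O=C(Nc1ccc2sc(-c3cccc(F)c3)nc2c1)N1CCCC1` changes compound 2 from phenyl to 3-fluorophenyl, with fluoro in place of hydrogen on an aromatic carbon. Because the limit of > 50000 nM in this assay, at which 2 of the 2 values shown sit, applies to both the phenyl and the 3,4-difluorophenyl compounds, no step beyond the scatter is expected in this assay and a further limit is the likeliest report. The estimated change is a number no higher from compound 2 to compound 3 (the limit leaves the size open) and it rests on limits alone. For compound 3 the expected value is 50000 nM with an estimated range from 20000 nM to 100000 nM as its span.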

Compound 3, half-maximal effective concentration: > 50000 nM
Compound 3: only a limit was reported; the forecaster's own chance of this, stated with the estimate: 85%; the middle value lies on the limit itself.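

In this assay compound 3 gives > 50000 nM, which is a limit and not a number. No step among compound 1, compound 2 and compound 3 can be read, and all three share the same ceiling: the limit of > 50000 nM in this assay, at which 3 of the 3 values shown sit.

The compounds shown leave open where the actual values lie and whether fluoro in place of hydrogen changes them at all.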